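The source may hold more compounds than are shown below. What is called first, only, known or untested is meant among the compounds shown, and "the series" means these compounds.

Measured compounds:
compound 1, `Cc1nc(S)n(Nc2ccc(Cl)cc2)c1-c1ccccc1` — 134000 nM
compound 2, `CC1N=C(S)N(Nc2cccc(Cl)c2)C1C` — 259000 nM

Both were tested in a functional assay on MT4 cells (Homo sapiens) for cytotoxicity; a lower number here means that less compound is tolerated, a higher number that more compound is tolerated. Compound 1 holds the lower of the two numbers, with 134000 nM; its nearest neighbour is compound 2, which in this assay gives 259000 nM, and that gap lies within the scatter, so the two cannot be told apart on these data. Compound 3, `Cc1nc(S)n(Nc2cccc(Cl)c2)c1-c1ccccc1`, has not yet been measured. It differs from compound 1 in a single place: 3-chlorophenyl in place of 4-chlorophenyl on a nitrogen on an aromatic ring. Compound 2 already carries a 3-chlorophenyl group, though on a different core, and its number does not stand apart from that of compound 1. For the measured compounds named here, no step between measured compounds exists to guide the size of this change. In this assay only a small step is expected, a 1.3-fold higher number from compound 1 to compound 3 (0.10 log units; within the scatter), not clearly beyond the scatter. Compound 3 is therefore estimated at 170000 nM, within a range from 85000 nM to 340000 nM.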

Compound 3, half-maximal cytotoxic concentration: 66700 nM
Estimate against measurement, compound 3: 2.5-fold (0.41 log units) above, and the stated range ends above it.
By their numbers in this assay, from the lowest: compounds 3, 1 and 2 (each within the scatter of the next, the first and the last beyond it).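

In this assay, the exchange of 4-chlorophenyl for 3-chlorophenyl on a nitrogen on an aromatic ring now has a measured size on the shared core, giving a 2.0-fold lower number from compound 1 to compound 3 (0.30 log units; within the scatter). The earlier compounds shown here offered no such step, since compound 1 and compound 2 differ in more than one place. On this core the two chlorophenyl groups therefore cannot be told apart in this assay, and nothing at hand speaks to the cause of this result.

The compounds shown leave open whether a group other than chlorophenyl on this nitrogen, such as unsubstituted phenyl, methoxyphenyl or carboxyphenyl, would give a step beyond the scatter. They also leave open whether the same exchange would give a step of similar size on the core of compound 2.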